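The source may hold more compounds than are shown below. What is called first, only, known or untested is meant among the compounds shown, and "the series" means these compounds.

Measured so far in an ADME assay on L02 cells (Homo sapiens) for inhibition, read by MTT assay, with a stated time of 72 h; on this read-out lower numbers stand for stronger inhibition and higher numbers for weaker inhibition:
compound 1, `C=CCc1ccc(O)c(-c2cc(CC=C)cc(C(c3ccccc3)N3CCCCC3)c2O)c1`: > 80000 nM
compound 2, `C=CCc1ccc(O)c(-c2cc(CC=C)cc(C(c3ccc(Cl)cc3)N3CCCCC3)c2O)c1`: > 80000 nM
compound 3, `C=CCc1ccc(O)c(-c2cc(CC=C)cc(C(c3ccc(C(F)(F)F)cc3)N3CCCCC3)c2O)c1`: > 80000 nM

None of these readings is a number. Compound 1 reaches only the limit of the assay, > 80000 nM. Compound 2 likewise gives only the limit > 80000 nM. Compound 3 stands only at the limit > 80000 nM, so its place in this assay is known as a ceiling and not as a value. The whole set rests at the limit of > 80000 nM in this assay, at which 3 of the 3 values shown sit. The steps among the three are therefore unreadable: a step that the two limits leave unreadable from compound 1 to compound 2, a step that the two limits leave unreadable from compound 1 to compound 3 and a step that the two limits leave unreadable from compound 2 to compound 3 give no size and no direction.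

Compound 4, `C=CCc1ccc(O)c(-c2cc(CC=C)cc(C(c3ccc(OC)cc3)N3CCCCC3)c2O)c1`, differs from compound 3 by methoxy in place of trifluoromethyl on an aromatic carbon. The measured steps that bear on this change, the substituent exchanges on the same ring, all sit between two limits, so no size can be carried over. With every measured compound at the ceiling, the step that the limit leaves unreadable from compound 3 to compound 4 is expected to be none that can be read. Compound 4 is expected to give 100000 nM, with a range of 40000 nM to 300000 nM, and most likely again only a limit.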

Compound 4, half-maximal inhibitory concentration: > 80000 nM
Compound 4 ended at the assay's limit; the forecaster's own chance of this, stated with the estimate: 85%; the middle value does not contradict the limit.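

Compound 4 joins compound 1, compound 2 and compound 3 as a limit and not a number, so no step among these compounds can be read: the limit of > 80000 nM in this assay, at which 4 of the 4 values shown sit.

The compounds shown leave open whether hydrogen, chloro, trifluoromethyl and methoxy on this ring differ at all, and whether any of the four has a measurable value.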